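The source may hold more compounds than are shown below. What is called first, only, known or untested is meant among the compounds shown, and "the series" means these compounds.

Measured so far in this series:
- compound 1 `Nc1nc(NCc2ccncc2)nc2sc(-c3ccco3)nc12`: 47 nM
- compound 2 `Nc1nc(NCc2ccco2)nc2sc(-c3ccco3)nc12`: 38 nM
- compound 3 `Nc1nc(NCc2cccnc2)nc2sc(-c3ccco3)nc12`: 7.12 nM

All three share one core and differ only in the group on a saturated chain carbon bound to a nitrogen on an aromatic ring. In an assay on CHO cells for displacement of a labelled ligand from adenosine receptor A1 (Homo sapiens), read by scintillation counting, with a stated time of 90 min (a higher number here means a weaker inhibitor, a lower number a stronger inhibitor), compound 3 gives 7.12 nM, the lowest of the three numbers; the nearest is compound 2, and the step of a 5.3-fold lower number from compound 2 to compound 3 (0.73 log units; beyond the scatter) lies beyond the scatter, as does a 6.6-fold lower number from compound 1 to compound 3 (0.82 log units; beyond the scatter). The step of a 1.2-fold lower number from compound 1 to compound 2 (0.09 log units; within the scatter) is within the scatter.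

Compound 4 `Nc1nc(NCc2cnccn2)nc2sc(-c3ccco3)nc12` is not yet measured. It differs from compound 3 by pyrazin-2-yl in place of pyridin-3-yl on a saturated chain carbon bound to a nitrogen on an aromatic ring. For the measured compounds named here, no measured step swaps one six-membered aromatic ring for another of the same kind with an added ring nitrogen, so the closest guides are the two steps into compound 3, which were modest and in the direction of a lower number, and the small step from compound 1 to compound 2, which shows that a ring change at this place can also leave the number unchanged. The expected step of a 2.1-fold higher number from compound 3 to compound 4 (0.32 log units; beyond the scatter) is therefore small, most likely back toward a somewhat higher number, with the range allowing no change. For compound 4 the estimate in this assay is 15 nM, between 4 nM and 50 nM.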

Compound 4, inhibition constant: 25 nM
The estimate for compound 4 lay 1.7-fold (0.22 log units) below the measured number; low and high end bracket the measured number.
By their numbers in this assay, from the lowest: compound 3; then compounds 4, 2 and 1 (each within the scatter of the next).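

In this assay, for the compounds shown here, the change from pyridin-3-yl to pyrazin-2-yl is the first step at this place to keep a six-membered aromatic ring while adding a ring nitrogen, and it gives a 3.5-fold higher number from compound 3 to compound 4 (0.55 log units; beyond the scatter); the low number of compound 3 therefore does not carry over to this closely related ring. Compound 4 falls in with the other two compounds, as a 1.5-fold lower number from compound 2 to compound 4 (0.18 log units; within the scatter) and a 1.9-fold lower number from compound 1 to compound 4 (0.27 log units; within the scatter) are both within the scatter, leaving the pyridin-3-yl group of compound 3 as the only one of the four that stands apart. The count of ring nitrogens does not order the series on its own: compound 3 and compound 1 each carry a ring with one, yet only compound 3 stands apart, while compound 4, with two, lies within the scatter of compound 1.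

No measurement at hand accounts for the separate standing of compound 3. Still open, as far as these compounds go, is how a plain phenyl ring, a pyrimidin-5-yl ring or a longer chain carrying pyridin-3-yl would read at this place, and so whether the ring nitrogen of compound 3 matters at all.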